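Naphthalenyl replacing methoxyphenyl on a piperazine-bearing thiophene core

The source may hold more compounds than are shown below. What is called first, only, known or untested is meant among the compounds shown, and "the series" means these compounds.

Measured compounds:
compound 1 `COc1ccc(N2CCN(Cc3csc(N)c3C(=O)c3ccc(Cl)cc3)CC2)cc1`, -15%
compound 2 `Nc1scc(CN2CCN(c3ccc(C(F)(F)F)cc3)CC2)c1C(=O)c1cccc(C(F)(F)F)c1`, -27%

Of the compounds shown here, two sharing a common core have been tested in a functional assay on CHO cells with adenosine receptor A1 (Homo sapiens) as the target, read by cAMP accumulation and immunoassay, with a stated time of 6 min, tested at 1 uM; a higher number here means a weaker effect of the compound at the concentration tested, a lower number a stronger effect. Compound 1 `COc1ccc(N2CCN(Cc3csc(N)c3C(=O)c3ccc(Cl)cc3)CC2)cc1` gives -15% in this assay, and compound 2 `Nc1scc(CN2CCN(c3ccc(C(F)(F)F)cc3)CC2)c1C(=O)c1cccc(C(F)(F)F)c1` gives -27%. Among the measured compounds shown here, of these two numbers, compound 1 stands highest; the nearest number, that of compound 2, lies lower by a margin beyond the usual scatter, so the two differ in more than one place and no single step between them is defined.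

Compound 3 `Nc1scc(CN2CCN(c3cccc4ccccc34)CC2)c1C(=O)c1ccc(Cl)cc1` has not yet been measured in this assay. It differs from compound 1 in one place: naphthalen-1-yl in place of 4-methoxyphenyl on an amine nitrogen in a ring. For the measured compounds named here, no step between measured compounds reproduces this exchange, so the only footing is the shared core and the values of compounds 1 and 2, both of which lie at the weak end of the read-out. The step from compound 1 to compound 3 is expected to be small, a number 3 percentage points lower from compound 1 to compound 3 (within the scatter), with no clear direction beyond the scatter. Compound 3 is estimated to give -18% in this assay, within a range from -42% to 6%.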

Compound 3, a percentage reported as activity, at one concentration (the size of the read-out at that concentration, not a potency): 2.9%
The estimate for compound 3 lay 20.9 percentage points below the measured number; measured number inside the range.
By their numbers in this assay, from the lowest: compound 2; then compound 1; then compound 3.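

In this assay, the group on the amine nitrogen in the ring proves not to be neutral: with the rest of compound 1 unchanged, naphthalen-1-yl in place of 4-methoxyphenyl gives a number 17.9 percentage points higher from compound 1 to compound 3 (beyond the scatter), which in this read-out means a weaker effect at the concentration tested. The step also carries the read-out across zero, since compound 3 gives 2.9%, a positive number where compound 1 gives -15%. This single exchange adds a second six-membered aromatic ring of carbon only and removes the hydrogen-bond acceptor of the leaving group at the same time, so the step alone cannot assign the change to either feature. Nothing measured here explains why the number moves.

The compounds shown leave open whether a plain phenyl group at this position would stay with compound 1 or move with compound 3, which would begin to separate the loss of the methoxy group from the gain of the second ring. They also leave open how a saturated ring such as cyclohexyl would read at the same place.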